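The compounds below may be only part of what the source reports. "The series", "measured", "known", "first", "only" and "open" are said of these compounds alone.

Compound 1 `CN(C)C(=O)c1cc2cnc(Nc3ccc(S(=O)(=O)NCCCCCCN=C=S)cc3)nc2n1C1CCCC1` is tested in a functional assay on NCI-H1299 cells (Homo sapiens) for inhibition, read by CCK-8 assay, with a stated time of 72 h, tested at 10 uM (on this read-out lower numbers stand for a weaker effect and higher numbers for a stronger effect at the one concentration tested), where compound 1 gives 70.6%. Compound 2 `CN(C)C(=O)c1cc2cnc(Nc3ccc(S(=O)(=O)NCCCCCCCN=C=S)cc3)nc2n1C1CCCC1` carries a group of 4 heavy atoms (2 carbon, 1 nitrogen, 1 sulfur; no ring) in place of a group of 3 heavy atoms (1 carbon, 1 nitrogen, 1 sulfur; no ring), on a saturated chain carbon, six bonds along the chain from a sulfonamide nitrogen, and in this assay compound 2 gives 83%, a step of a number 12.4 percentage points higher from compound 1 to compound 2 (beyond the scatter). Compound 3 `CN(C)C(=O)c1cc2cnc(Nc3ccc(C(=O)NCCCN=C=S)cc3F)nc2n1C1CCCC1` has a different core from compound 1; the difference between the two cores is not broken down here. In this assay compound 3 gives 78.5%, which lies within the scatter of both compound 2 and compound 1. Compound 4 `CN(C)C(=O)c1cc2cnc(Nc3ccc(C(=O)NCCCCN=C=S)cc3F)nc2n1C1CCCC1` is not yet measured. It differs from compound 3 by a group of 4 heavy atoms (2 carbon, 1 nitrogen, 1 sulfur; no ring) in place of a group of 3 heavy atoms (1 carbon, 1 nitrogen, 1 sulfur; no ring), on a saturated chain carbon, three bonds along the chain from an amide-type nitrogen. This is the same kind of change as that between compound 1 and compound 2, but not the same: there it sat six bonds along the chain from a sulfonamide nitrogen, here it sits three bonds along the chain from an amide-type nitrogen. For compound 4 a step of a number 4.5 percentage points higher from compound 3 to compound 4 (within the scatter) is expected in this assay, smaller than the earlier one, because the analogous change gave a number 12.4 percentage points higher from compound 1 to compound 2 (beyond the scatter) on a different core and at a different place. Compound 4 is thus estimated at 83%, between 72% and 92%.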

Compound 4, a percentage reported as inhibition, at one concentration (the size of the read-out at that concentration, not a potency): 78.9%
Estimate against measurement, compound 4: 4.1 percentage points above, within the range that was stated.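

In this assay, putting the group of 4 heavy atoms in place of the group of 3 heavy atoms on the core of compound 3 gives a step of a number 0.4 percentage points higher from compound 3 to compound 4 (within the scatter), so at this place the change does not separate the two compounds. Set beside the earlier step on the core of compound 1, the new step cannot be told apart from it: the same change on two cores in this assay, a number 12.4 percentage points higher (beyond the scatter) from compound 1 to compound 2 and a number 0.4 percentage points higher (within the scatter) from compound 3 to compound 4, 12 percentage points apart, within the scatter of two such steps. This shows neither that the change carries over between the cores with the same size nor that its size depends on the core, and the two cases also differ in place, six bonds along the chain from a sulfonamide nitrogen in one and three bonds along the chain from an amide-type nitrogen in the other, which leaves core and place unseparated.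

The compounds shown leave open whether a longer chain on the amide-type nitrogen would give a step beyond the scatter. They also leave open how an amine or a carboxylic acid would read in place of the group that closes the chain in all four compounds.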